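The compounds below may be only part of what the source reports. "The series", "measured", "known", "first", "only" and "open" are said of these compounds alone.

Measured compounds:
- compound 1, `COc1cc(Cl)cc(-c2nn(-c3cccc(NC(=O)Nc4ccc(Cl)c(C(F)(F)F)c4)c3)cc2-c2ccncc2)c1`: 99%
- compound 2, `COc1cc(Cl)cc(-c2nn(-c3cccc(NC(=O)Nc4ccc(Cl)c(Cl)c4)c3)cc2-c2ccncc2)c1`: 98%

In a functional assay on BT-549 cells (Homo sapiens) for inhibition, read by sulforhodamine B assay, with a stated time of 48 h, tested at 0.1 uM (on this read-out lower numbers stand for a stronger effect and higher numbers for a weaker effect at the one concentration tested), compound 1 gives 99% and compound 2 gives 98%. Among the measured compounds shown here, the single measured step, a number 1 percentage points lower from compound 1 to compound 2 (within the scatter), is the change of chloro in place of trifluoromethyl on an aromatic carbon, and it stays within the scatter. Compound 2 thus stands as the lower of the two numbers on this read-out, with compound 1 only one point apart, a gap that means nothing.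

Compound 3, `COc1cc(Cl)cc(-c2nn(-c3cccc(NC(=O)Nc4cccc(C(F)(F)F)c4)c3)cc2-c2ccncc2)c1`, has not yet been measured in this assay. The change from compound 2 is 3-(trifluoromethyl)phenyl in place of 3,4-dichlorophenyl on an amide-type nitrogen. For the measured compounds named here, no measured step alters the same place in the same way, so the only guidance is that the swap between trifluoromethyl and chloro on that aryl gave a number 1 percentage points lower from compound 1 to compound 2 (within the scatter), and that both compound 1 and compound 2 sit at near-full activity in this assay. On that basis compound 3 is expected to show a step of a number 1 percentage points lower from compound 2 to compound 3 (within the scatter), that is none beyond the scatter. The value of compound 3 is estimated at 97%, within 85% to 106%.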

Compound 3, a percentage reported as activity, at one concentration (the size of the read-out at that concentration, not a potency): 114%
Compound 3: middle estimate off by 17 percentage points, on the low side; measured number above the stated range.
By their numbers in this assay, from the lowest: compounds 2 and 1 (each within the scatter of the next); then compound 3.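

In this assay, the aryl group on the amide-type nitrogen proved sensitive after all: the earlier exchange of trifluoromethyl for chloro gave only a number 1 percentage points lower from compound 1 to compound 2 (within the scatter), whereas hydrogen in place of chloro on an aromatic carbon gives a number 15 percentage points higher from compound 1 to compound 3 (beyond the scatter). Compound 1 and compound 2 both carry that chloro and compound 3 lacks it, and 3-(trifluoromethyl)phenyl in place of 3,4-dichlorophenyl gives a number 16 percentage points higher from compound 2 to compound 3 (beyond the scatter), so in these three compounds the loss of that one chloro goes with a higher number, and thus a weaker effect at the single concentration tested, whichever of the two other groups accompanies it. Nothing presented here accounts for this shift.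

The compounds shown leave open whether the chloro itself matters or whether another group at that carbon, such as a methyl, a nitrile or an amine, would keep the number where compound 1 and compound 2 stand. They also leave open whether the same step would appear at other concentrations, and whether it would hold with other groups on the shared core.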